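Compound 2 to compound 3: expected activity

The source may report more compounds than this note shows. Statements on the series, on what has been measured and on what is new or still open speak of the compounds shown alone.

Measured so far:
compound 1 `Nc1scc(CN2CCN(c3cc(Cl)cc(Cl)c3)CC2)c1C(=O)c1ccc(Cl)cc1` gives -22% in a functional assay on CHO cells with adenosine receptor A1 (Homo sapiens) as the target, read by cAMP accumulation and immunoassay, with a stated time of 6 min, tested at 0.1 uM; on this read-out lower numbers stand for a stronger effect and higher numbers for a weaker effect at the one concentration tested
compound 2 `COc1ccc(N2CCN(Cc3csc(N)c3C(=O)c3ccc(Cl)cc3)CC2)cc1` gives 0% in this assay

Compound 2 holds the higher of the two numbers. Going by the values given here, the only measured step, a number 22 percentage points higher from compound 1 to compound 2 (beyond the scatter), comes from 4-methoxyphenyl in place of 3,5-dichlorophenyl on an amine nitrogen in a ring. Compound 3 `Nc1scc(CN2CCN(c3ccc(OC(F)(F)F)cc3)CC2)c1C(=O)c1ccc(Cl)cc1` differs from compound 2 by trifluoromethyl in place of methyl on an oxygen on an aromatic ring. Among the compounds with values here, no measured step touches the group on this oxygen, so the aryl swap offers no direct guide. The change from compound 2 to compound 3 is expected to be a number 5 percentage points lower from compound 2 to compound 3 (within the scatter), nothing beyond the scatter. Compound 3 is expected near -5%, between -25% and 15%.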

Compound 3, a percentage reported as activity, at one concentration (the size of the read-out at that concentration, not a potency): -13%
Estimate against measurement, compound 3: 8 percentage points above; the measured number falls inside the stated range.
By their numbers in this assay, from the lowest: compounds 1 and 3 (each within the scatter of the next); then compound 2.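

In this assay, going by these compounds alone, the group on the oxygen on the aromatic ring does matter: trifluoromethyl in place of methyl gives a number 13 percentage points lower from compound 2 to compound 3 (beyond the scatter) and is the only measured step at this oxygen. The aryl group on the amine nitrogen in a ring is also less decisive than the earlier step alone suggested, since 4-(trifluoromethoxy)phenyl in place of 3,5-dichlorophenyl gives a number 9 percentage points higher from compound 1 to compound 3 (within the scatter) and only 4-methoxyphenyl stands apart. No evidence available here accounts for this difference between methyl and trifluoromethyl.

As far as these compounds go, whether ethyl or difluoromethyl on this oxygen would read like compound 2 or like compound 3 remains open. So does the outcome of replacing the whole 4-(trifluoromethoxy)phenyl with an unsubstituted phenyl.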